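Turning the Amide Around on a Shared Core

A few compounds are considered here, and "the series" means these few. Any claim that something is new, unique, unknown or untested is made for them only; others in the source may bear on it.

Compound 3 `Cc1cc(C(=O)NCc2cccnc2)nn1Cc1cc(Cl)ccc1OCc1ccccc1` gives the lowest of the three measured numbers in an assay on CHO-K1 cells for displacement of a labelled ligand from prostaglandin E2 receptor EP1 subtype (Homo sapiens) (on this read-out higher numbers stand for weaker inhibition and lower numbers for stronger inhibition), namely 50.1 nM. Compound 1 `Cc1cc(C(N)=O)nn1Cc1cc(Cl)ccc1OCc1ccccc1` gives 126 nM, and compound 2 `Cc1cc(C(=O)Nc2cccc(F)c2)nn1Cc1cc(Cl)ccc1OCc1ccccc1` gives 200 nM. The steps of a 2.5-fold lower number from compound 1 to compound 3 (0.40 log units; beyond the scatter) and a 4.0-fold lower number from compound 2 to compound 3 (0.60 log units; beyond the scatter) show that the group on the amide nitrogen shifts the number modestly, whereas a 1.6-fold higher number from compound 1 to compound 2 (0.20 log units; within the scatter) stays within the scatter. Compound 4 `Cc1cc(NC(=O)CC2CCCCC2)nn1Cc1cc(Cl)ccc1OCc1ccccc1` makes a different kind of change: ((cyclohexylmethyl)carbonyl)amino in place of ((pyridin-3-yl)methyl)carbamoyl on an aromatic carbon. Within the data shown here, no measured step covers turning the amide around or bringing in a saturated ring in place of an aromatic one, so the direction stays open, and the measured spread around this position is modest in either direction. A small step of a 3.0-fold higher number from compound 3 to compound 4 (0.48 log units; beyond the scatter) is therefore expected. The number for compound 4 is estimated at 150 nM, between 40 nM and 600 nM.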

Compound 4, half-maximal inhibitory concentration: 6.31 nM
The estimate for compound 4 lay 24-fold (1.38 log units) above the measured number; measured number below the stated range.
By their numbers in this assay, from the lowest: compound 4; then compound 3; then compounds 1 and 2 (each within the scatter of the next).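

Placing ((cyclohexylmethyl)carbonyl)amino on this aromatic carbon gives a 7.9-fold lower number from compound 3 to compound 4 (0.90 log units; beyond the scatter), along with a 20-fold lower number from compound 1 to compound 4 (1.30 log units; beyond the scatter) and a 32-fold lower number from compound 2 to compound 4 (1.50 log units; beyond the scatter). These steps show that this position can support a much lower number in this assay than any of the three earlier amides reached, with compound 4 the lowest of the four. As far as these compounds go, the turned-around amide and the saturated ring enter together, so their separate contributions stay open, as does the outcome with a piperidine ring or a longer carbon chain in place of the cyclohexylmethyl part. No available evidence accounts for the drop.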